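Urea series: trifluoromethyl in place of heptyl

A few compounds are considered here, and "the series" means these few. Any claim that something is new, unique, unknown or untested is made for them only; others in the source may bear on it.

Compound 1 `Cc1ccc(NC(=O)N[C@@H](C)c2ccccc2)cc1`, compound 2 `CCCCCc1ccc(NC(=O)N[C@@H](C)c2ccccc2)cc1` and compound 3 `CCCCCCCc1ccc(NC(=O)N[C@@H](C)c2ccccc2)cc1` share one core and differ only in the chain attached to its aromatic ring. In an ADME assay on the whole organism with Oryza sativa as the target, tested at 0.1 uM (on this read-out higher numbers stand for a weaker effect at the one concentration tested and lower numbers for a stronger effect), compound 1 gives 100%, compound 2 gives 98% and compound 3 gives 100%. Compound 3 thus stands level with compound 1 at the digits shown, the two together the highest of the three numbers; its nearest neighbour is compound 1, its furthest compound 2. The measured steps are all small: a number 2 percentage points lower from compound 1 to compound 2 (within the scatter), no change at the digits printed from compound 1 to compound 3 (within the scatter) and a number 2 percentage points higher from compound 2 to compound 3 (within the scatter).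

Compound 4 `C[C@H](NC(=O)Nc1ccc(C(F)(F)F)cc1)c1ccccc1` is not yet measured. Against compound 3 the change is trifluoromethyl in place of heptyl on an aromatic carbon. Going by the values given here, each measured step lengthens or shortens the chain on that aromatic carbon, and none moved the read-out beyond the scatter; no measured step replaces the chain by a group other than a chain, so the present change is only partly covered. Among the compounds with values here, with every value so far near the top of the scale, the expectation is no step beyond the scatter, and the estimated step is a number 1 percentage points lower from compound 3 to compound 4 (within the scatter). Compound 4 is therefore expected to give about 99% in this assay, with a range from 88% to 105%.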

Compound 4, a percentage reported as activity, at one concentration (the size of the read-out at that concentration, not a potency): 94%
For compound 4 the middle estimate is 5 percentage points above the measured one, and the stated range covers the measured number.
By their numbers in this assay, from the lowest: compounds 4, 2, 1 and 3 (each within the scatter of the next).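

Trifluoromethyl on this aromatic carbon is the first group in the series that is not a saturated chain, and in this assay the exchange for heptyl gives a number 6 percentage points lower from compound 3 to compound 4 (within the scatter) and stays on the same footing as the exchanges for the shorter chains, with a number 4 percentage points lower from compound 2 to compound 4 (within the scatter) for pentyl and a number 6 percentage points lower from compound 1 to compound 4 (within the scatter) for methyl. The position, para to a large group, therefore shows no step beyond the scatter in this assay for a fluorinated group any more than for a change in chain length, so all four compounds remain level within the scatter on this read-out. No supporting measurement bears on this result, so it stands as an observation without an explanation.

Going by these compounds, the shared core has so far carried only groups with no hydrogen-bond donors or acceptors at this aromatic carbon, so it remains open whether an amine, a carboxylic acid or a nitrile there would give a step beyond the scatter. Because every value sits at one concentration, these numbers also leave open whether any of the four compounds would separate from the others at a higher concentration.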